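From Phenol Ring to Iodophenyl on the Vinyl Carbon

This account rests on a few compounds, and the source may have more. Where it says the series, first, only, none or still open, it means among the compounds named here.

Measured compounds:
compound 1, `COc1cc(/C=C(/Sc2ccc(Br)cc2)C(=O)c2ccc(Br)cc2)ccc1O` — 1000 nM
compound 2, `COc1ccc(/C=C(\C(=O)c2ccc(Cl)cc2)S(=O)(=O)Cc2ccc(Cl)cc2)c(OC)c1OC` — 10000 nM

Two compounds have been run in a functional assay on DU-145 cells (Homo sapiens) for inhibition, read by trypan blue exclusion, with a stated time of 96 h; on this read-out higher numbers stand for weaker inhibition of growth and lower numbers for stronger inhibition of growth. Compound 1 gives 1000 nM, the lower of the two numbers. Compound 2 gives 10000 nM, and its gap to compound 1 lies beyond the usual scatter, so the two compounds are clearly separated on this read-out. The two structures differ in more than one place, so nothing can be said about which of their differences carries that gap.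

Compound 3, `O=C(/C(=C\c1ccc(I)cc1)Sc1ccc(Br)cc1)c1ccc(Br)cc1`, has not yet been measured. It differs from compound 1 in one place: 4-iodophenyl in place of 4-hydroxy-3-methoxyphenyl on a double-bonded chain carbon bound to a double-bonded chain carbon The entering group carries no hydrogen-bond donors and no hydrogen-bond acceptors, whereas the leaving group carried both.

Going by the values given here, no measured pair shows this kind of change, so the expectation rests on compound 1 alone, anchored by its value 1000 nM. A moderate weakening is expected, a 2.5-fold higher number from compound 1 to compound 3 (0.40 log units; beyond the scatter), though the data do not rule out a step that stays within the scatter. Compound 3 is therefore estimated at 2500 nM, with a plausible range from 600 nM to 10000 nM.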

Compound 3, concentration for 50% growth inhibition: 1000 nM
Compound 3: the middle estimate sits 2.5-fold (0.40 log units) above what was measured; low and high end bracket the measured number.
By their numbers in this assay, from the lowest: compounds 1 and 3 (each within the scatter of the next); then compound 2.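

In this assay, putting 4-iodophenyl in place of 4-hydroxy-3-methoxyphenyl on a double-bonded chain carbon bound to a double-bonded chain carbon gives no change at the digits printed from compound 1 to compound 3 (within the scatter). Going by these compounds alone, this is the first single-place comparison, and it shows that, for this pair, a group with no hydrogen-bond donors and no hydrogen-bond acceptors reads the same within the scatter as one that carried both, so the phenol hydroxyl and methoxy groups of compound 1 are not needed at this position to keep the growth-inhibition number of compound 1. No evidence on why the two compounds read alike is available here.

One pair cannot show whether this holds for other groups at this position, such as 4-aminophenyl, a phenyl ring bearing a carboxylic acid, or a plain alkyl chain, or whether it would hold on a different core, such as that of compound 2. Which of the several differences between compound 1 and compound 2 carries the gap between them also remains open, since no single-place step links those two compounds.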